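A few compounds are considered here, and "the series" means these few. Any claim that something is new, unique, unknown or untested is made for them only; others in the source may bear on it.

Compound 1 `CC(=O)O[C@@H]1[C@H](OC(C)=O)[C@@H](C[S+](C)[O-])O[C@H]1n1cnc2c(N)nc(Cl)nc21` and compound 3 `CC(=O)O[C@@H]1[C@H](OC(C)=O)[C@@H](CS(C)(=O)=O)O[C@H]1n1cnc2c(N)nc(Cl)nc21` are built on one shared core, while compound 2 `C[S+]([O-])C[C@H]1O[C@@H](n2cnc3c(N)nc(F)nc32)[C@H](O)[C@@H]1O` and compound 4 `CS(=O)(=O)C[C@H]1O[C@@H](n2cnc3c(N)nc(F)nc32)[C@H](O)[C@@H]1O` are built on another; the difference between the two cores is not broken down here. Three of the four have been tested in an ADME assay on L6 cells (Rattus norvegicus) for inhibition, read by resazurin assay, with a stated time of 72 h; on this read-out higher numbers stand for weaker inhibition and lower numbers for stronger inhibition. In this assay compound 1 gives 168000 nM, compound 3 gives 114000 nM, and compound 2 gives 13000 nM, the lowest of the three numbers, with its gaps to both others lying beyond the usual scatter.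

From compound 1 to compound 3 the change is a group of 4 heavy atoms (1 carbon, 2 oxygen, 1 sulfur; no ring) in place of a group of 3 heavy atoms (1 carbon, 1 oxygen, 1 sulfur; no ring), on a saturated chain carbon bound to a saturated ring carbon, and it produced a 1.5-fold lower number from compound 1 to compound 3 (0.17 log units; within the scatter). Compound 4 stands to compound 2 exactly as compound 3 stands to compound 1: the change is a group of 4 heavy atoms (1 carbon, 2 oxygen, 1 sulfur; no ring) in place of a group of 3 heavy atoms (1 carbon, 1 oxygen, 1 sulfur; no ring), on a saturated chain carbon bound to a saturated ring carbon, the same change at the same place.

Because a 1.5-fold lower number from compound 1 to compound 3 (0.17 log units; within the scatter) was a small step, a similarly small step is expected here, a 1.3-fold lower number from compound 2 to compound 4 (0.11 log units; within the scatter). Compound 4 is therefore estimated at 10000 nM, with a likely range from 4000 nM to 30000 nM.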

Compound 4, half-maximal inhibitory concentration: 5000 nM
Compound 4: the middle estimate sits 2.0-fold (0.30 log units) above what was measured; low and high end bracket the measured number.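

On the core of compound 2, methylsulfonyl in place of the smaller sulfur-bearing group gives a 2.6-fold lower number from compound 2 to compound 4 (0.41 log units; beyond the scatter) in this assay. Set beside the same change on the other core, the two steps agree as closely as this kind of measurement can tell, so the change carried over between these two cores without a detectable difference: the same change on two cores in this assay, a 1.5-fold lower number (0.17 log units; within the scatter) from compound 1 to compound 3 and a 2.6-fold lower number (0.41 log units; beyond the scatter) from compound 2 to compound 4, 1.8-fold (0.25 log units) apart, within the scatter of two such steps

Among these compounds, this is one pair of steps on two cores, and only the step on the core of compound 2 clears the scatter, so it does not show that the lower number is a general result of the change, that the change would behave alike on a third core, or why the numbers move.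

Open, from the compounds shown here alone, is how other groups on a saturated chain carbon bound to a saturated ring carbon would compare, such as a sulfide, an amine, a carboxylic acid or a longer chain on the sulfur. Also open, going by these compounds, is how much of the gap between the two cores comes from each of their differences.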